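The source may report more compounds than this note shows. Statements on the series, on what has been measured and on what is new or still open speak of the compounds shown alone.

Measured compounds:
compound 1, `COc1cccc(NC2=CC(=O)c3nc4n(c3C2=O)[C@H]2OC[C@@H](O)[C@H]2OC4)c1` — 1780 nM
compound 2, `O=C1C(N2CCCC2)=CC(=O)c2c1nc1n2[C@H]2OC[C@@H](O)[C@H]2OC1` — > 16000 nM

Among the measured compounds shown here, in a functional assay on MGC-803 cells (Homo sapiens) for inhibition, read by sulforhodamine B assay (on this read-out lower numbers stand for stronger inhibition and higher numbers for weaker inhibition), compound 1 gives 1780 nM, the only number in hand for the series. For compound 2 the assay returns only a limit, > 16000 nM, not a number; this is the limit of > 16000 nM in this assay, at which 1 of the 2 values shown sits. For the measured compounds named here, no pair of measured compounds differs in a single place, so no measured step is available, and of compound 1 and compound 2 only their two values can be noted as they stand.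

The step considered here is that from compound 1 to compound 3, `CCOc1ccccc1NC1=CC(=O)c2nc3n(c2C1=O)[C@H]1OC[C@@H](O)[C@H]1OC3`. The change is 2-ethoxyphenyl in place of 3-methoxyphenyl on an amine nitrogen; the shared core and the amine nitrogen are kept, and only the aryl group on that nitrogen is exchanged.

Going by the values given here, with no measured step to lean on, the expected step from compound 1 to compound 3 in this assay is a 1.4-fold higher number from compound 1 to compound 3 (0.15 log units; within the scatter), taken as small, most likely no further than the usual scatter, with no preferred direction. Compound 3 is therefore estimated at 2500 nM in this assay, within a range of 800 nM to 9000 nM.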

Compound 3, half-maximal inhibitory concentration: 2450 nM
Estimate against measurement, compound 3: 1.0-fold (0.01 log units) above; the measured number falls inside the stated range.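

The series now has its first measured step in this assay, and it is a 1.4-fold higher number from compound 1 to compound 3 (0.14 log units; within the scatter) for 2-ethoxyphenyl in place of 3-methoxyphenyl on an amine nitrogen. At this position, then, these two aryl groups cannot be told apart on this read-out, so the nitrogen carries either of them with no change beyond the scatter. The exchange alters the ether chain and its place on the ring together, so this single step does not separate the two, and nothing measured here gives a reason for its size.

The compounds shown leave open whether 2-methoxyphenyl or 3-ethoxyphenyl would read the same way, which would pull the chain apart from its place on the ring. They also leave open whether a phenyl ring carrying a carboxylic acid, a basic amine or a longer alkoxy chain would move the number beyond the scatter, and so how much variation this position on the nitrogen accepts.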